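The source may report more compounds than this note shows. Statements on the series, on what has been measured and on what is new or still open speak of the compounds shown alone.

Three compounds share one core and differ only in the aryl group on an amine nitrogen in a ring. Compound 1 `COc1ccc(N2CCN(Cc3csc(N)c3C(=O)c3ccc(Cl)cc3)CC2)cc1` gives -1.2% in a functional assay on CHO cells with adenosine receptor A1 (Homo sapiens) as the target, read by cAMP accumulation and immunoassay, with a stated time of 6 min, tested at 0.01 uM; a lower number here means a stronger effect, a higher number a weaker effect of the compound at the concentration tested. Compound 2 `Nc1scc(CN2CCN(c3cccnc3)CC2)c1C(=O)c1ccc(Cl)cc1` gives 3.2% in the same assay, and the step of a number 4.4 percentage points higher from compound 1 to compound 2 (within the scatter) shows that a pyridin-3-yl in place of 4-methoxyphenyl on an amine nitrogen in a ring changes little. Compound 3 `Nc1scc(CN2CCN(c3cc(F)cc(F)c3)CC2)c1C(=O)c1ccc(Cl)cc1` gives -13%; it stands lowest of the three, with a number 11.8 percentage points lower from compound 1 to compound 3 (beyond the scatter) and a number 16.2 percentage points lower from compound 2 to compound 3 (beyond the scatter) both beyond the scatter, though each step is modest in size.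

Compound 4 `Nc1scc(CN2CCN(c3cc(Cl)ccc3Cl)CC2)c1C(=O)c1ccc(Cl)cc1` is the next member, differing from compound 3 as follows: 2,5-dichlorophenyl in place of 3,5-difluorophenyl on an amine nitrogen in a ring. The three measured steps all concern the same aryl group on the ring nitrogen, and their sizes range from within the scatter to modest. A move from 3,5-difluorophenyl to 2,5-dichlorophenyl is therefore expected to give a step no larger than those seen, possibly none beyond the scatter, with the number staying near the low end of the series. Compound 4 is thus estimated at -8%, within a range from -25% to 9%, which corresponds to an expected step of a number 5 percentage points higher from compound 3 to compound 4 (within the scatter).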

Compound 4, a percentage reported as activity, at one concentration (the size of the read-out at that concentration, not a potency): 13%
For compound 4 the middle estimate is 21 percentage points below the measured one, and the stated range ends below it.
By their numbers in this assay, from the lowest: compound 3; then compounds 1, 2 and 4 (each within the scatter of the next, the first and the last beyond it).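

Swapping 3,5-difluorophenyl for 2,5-dichlorophenyl on the amine nitrogen in the ring gives a number 26 percentage points higher from compound 3 to compound 4 (beyond the scatter) in this assay, even though both groups have the same count of heavy atoms, a single carbon-only aromatic ring, no hydrogen-bond donors or acceptors and no net charge, so these shared counts do not fix the read-out at this position. The two halogen-bearing phenyl groups thus lie beyond the scatter of each other, and compound 4 also separates from the 4-methoxyphenyl member with a number 14.2 percentage points higher from compound 1 to compound 4 (beyond the scatter) while it cannot be told apart from the pyridin-3-yl member, with a number 9.8 percentage points higher from compound 2 to compound 4 (within the scatter) as the step. Nothing measured here accounts for these differences.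

The halogen and its place on the phenyl ring change together in this step, which leaves open which of the two goes with the shift, and a 3,5-dichlorophenyl or 2,5-difluorophenyl group on the same nitrogen would bear on that. Also open, from the compounds shown here alone, is how a group without an aromatic ring, such as cyclohexyl, would read at this position, and whether the differences seen at this single concentration would hold at others.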